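This account rests on a few compounds, and the source may have more. Where it says the series, first, only, none or still open, it means among the compounds named here.

Three compounds on the shared core have numbers in a functional assay on HepG2 cells (Homo sapiens) for inhibition, read by MTT assay, with a stated time of 48 h; on this read-out higher numbers stand for weaker inhibition and lower numbers for stronger inhibition: compound 1 (`CCOC(=O)C1=C(N/C=N/c2cccnc2Cl)Nc2[nH]nc(C)c2C1c1ccc(N(C)C)cc1`) gives 4890 nM, compound 2 (`CCOC(=O)C1=C(N/C=N/c2ccc(C)cc2)Nc2[nH]nc(C)c2C1c1ccc(N(C)C)cc1`) gives 44400 nM and compound 3 (`CCOC(=O)C1=C(N/N=C(/Cl)C#N)Nc2[nH]nc(C)c2C1c1ccc(N(C)C)cc1`) gives 23600 nM. Compound 3 stands in the upper pair of these numbers. The gap to its partner is a 1.9-fold lower number from compound 2 to compound 3 (0.27 log units; within the scatter), and the gap to the remaining number is a 4.8-fold higher number from compound 1 to compound 3 (0.68 log units; beyond the scatter).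

The next structure is compound 4 (`CCOC(=O)C1=C(N/N=C(/C(=O)Br)c2ccc(Cl)cc2)Nc2[nH]nc(C)c2C1c1ccc(N(C)C)cc1`), and the change is a group of 12 heavy atoms (8 carbon, 1 nitrogen, 1 oxygen, 1 chlorine, 1 bromine; one six-membered aromatic ring of carbon only) in place of a group of 5 heavy atoms (2 carbon, 2 nitrogen, 1 chlorine; no ring), on an amine nitrogen. Among the compounds with values here, no measured compound carries the entering group, so the evidence is indirect. Within the data shown here, the nearest precedent is compound 2, whose group on the same amine nitrogen also holds a six-membered aromatic ring of carbon only, and its exchange for the ringless group of compound 3 gave a 1.9-fold lower number from compound 2 to compound 3 (0.27 log units; within the scatter). Compound 1 holds a ring with a hetero atom instead, and its exchange gave the larger step already noted. The ring swap alone gave a 9.1-fold higher number from compound 1 to compound 2 (0.96 log units; beyond the scatter), so the range has to stay wide.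

The estimated step is a 1.5-fold lower number from compound 3 to compound 4 (0.17 log units; within the scatter), meaning that no change beyond the scatter is expected in this assay. Compound 4 is estimated at 16000 nM, with an expected range of 4000 nM to 50000 nM.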

Compound 4, half-maximal inhibitory concentration: 50300 nM
Compound 4: middle estimate off by 3.1-fold (0.50 log units), on the low side, outside the stated range (above it).
By their numbers in this assay, from the lowest: compound 1; then compounds 3, 2 and 4 (each within the scatter of the next, the first and the last beyond it).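

In this assay, the group of 12 heavy atoms on the amine nitrogen gives a 2.1-fold higher number from compound 3 to compound 4 (0.33 log units; beyond the scatter) and, against the other group holding a six-membered aromatic ring of carbon only, a 1.1-fold higher number from compound 2 to compound 4 (0.05 log units; within the scatter), so a large entering group with such a ring does not bring the number down towards that of compound 1 at this position. Within the data shown here, the step of a 10-fold higher number from compound 1 to compound 4 (1.01 log units; beyond the scatter) is the largest yet seen in this small set, and compound 1, the only compound with a six-membered aromatic ring with 1 hetero atom, remains alone at the low end, with its steps to compound 2, compound 3 and compound 4 all printed as beyond the scatter. No measurement on hand accounts for these steps, so they stand as description only.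

The entering group differs from the others in several parts at once, so the compounds shown do not separate the contribution of the carbonyl with its bromine from that of the chlorine-bearing aromatic ring. Also open, from the compounds shown here alone, is whether a carboxylic acid or a simple amide in place of that carbonyl with its bromine, or a ring with 1 hetero atom on the same framework as compound 4, would move the number towards that of compound 1.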